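Removing the Methoxy Group from a Thiazole Acetic Acid

The source may hold more compounds than are shown below. What is called first, only, known or untested is meant among the compounds shown, and "the series" means these compounds.

Of the compounds shown here, two sharing one core have been measured in an in vitro assay on COS-7 cells for displacement of a labelled ligand from prostaglandin D2 receptor 2 (Homo sapiens) (on this read-out higher numbers stand for weaker inhibition and lower numbers for stronger inhibition), so far. Compound 1 `COc1ccc(-c2nc(Nc3ccccc3)sc2CC(=O)O)cc1` gives 1900 nM. Compound 2 `COc1ccc(-c2nc(-c3ccc(OC)cc3)c(CC(=O)O)s2)cc1` gives 4100 nM. Among the measured compounds shown here, the one measured step, a 2.2-fold higher number from compound 1 to compound 2 (0.33 log units; beyond the scatter), swaps an anilino group for a 4-methoxyphenyl group. Compound 2 therefore stands as the higher of the two numbers, beyond the scatter from compound 1.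

Compound 3 `COc1ccc(-c2nc(-c3ccccc3)c(CC(=O)O)s2)cc1` differs from compound 2 by hydrogen in place of methoxy on an aromatic carbon, on an aromatic carbon of a six-membered aromatic ring of carbon only, para to a large group; cut one bond further out, the change reads 4-methoxyphenyl to phenyl.

For the measured compounds named here, no measured step touches this position: the step from compound 1 to compound 2 changed a different part of the molecule, so it gives no direct guide to what losing the methoxy group does. With nothing to anchor a direction, the expected step of a 1.0-fold lower number from compound 2 to compound 3 (0.01 log units; within the scatter) is none beyond the scatter, with a wide range to allow for surprise. Compound 3 is therefore estimated at 4000 nM, expected to fall between 1500 nM and 11000 nM.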

Compound 3, half-maximal inhibitory concentration: 820 nM
For compound 3 the middle estimate is 4.9-fold (0.69 log units) above the measured one, outside the stated range (below it).
By their numbers in this assay, from the lowest: compound 3; then compound 1; then compound 2.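

In this assay, this position on the ring matters: replacing methoxy with hydrogen gives a 5.0-fold lower number from compound 2 to compound 3 (0.70 log units; beyond the scatter), so the smaller phenyl group goes with stronger inhibition than the 4-methoxyphenyl group it replaces. Among the compounds shown here, this is the first view of a change on this aromatic carbon, para to a large group, since the earlier step altered a different part of the molecule and could say nothing about this place. Nothing available explains why dropping the methoxy group has this effect, so the step stands as an observation and no more.

The compounds shown cannot tell whether what matters is the absence of methoxy itself or whether another small group, such as fluorine, methyl or hydroxy, would fit equally well on this carbon. From the compounds shown here alone, it also remains open whether replacing the 4-methoxyphenyl group that compound 3 still carries with a plain phenyl group would move the number in the same direction.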